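Sulfonyl substituent swap: isopropyl analogue of the hydroxypyrrolidine

The source may hold more compounds than are shown below. What is called first, only, known or untested is meant among the compounds shown, and "the series" means these compounds.

Compound 1 `O=C([C@@H]1CCCN(S(=O)(=O)c2ccc(S(=O)(=O)C3CCC3)cc2)C1)N1CCC(F)(F)CC1`, compound 2 `O=C([C@@H]1CCCN(S(=O)(=O)c2ccc(S(=O)(=O)N3CC[C@@H](O)C3)cc2)C1)N1CCC(F)(F)CC1` and compound 3 `CCN(CC)S(=O)(=O)c1ccc(S(=O)(=O)N2CCC[C@@H](C(=O)NC3COC3)C2)cc1` share a core and differ at one sulfonyl sulfur and elsewhere. In an ADME assay on microsomes from liver (Homo sapiens) for metabolic stability, read by LC-MS, using NADPH, with a stated time of 60 min, tested at 10 uM (on this read-out higher numbers stand for a longer-lived compound and lower numbers for a shorter-lived compound), compound 1 gives only a limit, > 1 h. That value sits at the limit of > 1 h in this assay, at which 1 of the 3 values shown sits. In this assay compound 2 gives 0.517 h and compound 3 gives 0.308 h; these two lie within the scatter of each other, so neither is set apart. Among the compounds with values here, the single measured step, an at least 1.9-fold lower number from compound 1 to compound 2 (0.28 log units; that floor lies within the scatter), went with cyclobutyl giving way to 3-hydroxypyrrolidin-1-yl. Compound 4 `CC(C)S(=O)(=O)c1ccc(S(=O)(=O)N2CCC[C@@H](C(=O)N3CCC(F)(F)CC3)C2)cc1` runs in the opposite sense: isopropyl in place of 3-hydroxypyrrolidin-1-yl on a sulfonyl sulfur. A rise in this assay is therefore expected, estimated as a 1.7-fold higher number from compound 2 to compound 4 (0.24 log units; within the scatter). Compound 4 is expected near 0.9 h, within 0.5 h to 1.6 h, quite possibly returning a limit.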

Compound 4, half-life: > 1 h
Compound 4 was reported as a limit; the forecaster's own chance of this, stated with the estimate: 45%; at least 1.1-fold (0.04 log units) between middle value and limit.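

In this assay, isopropyl in place of 3-hydroxypyrrolidin-1-yl on a sulfonyl sulfur gives an at least 1.9-fold higher number from compound 2 to compound 4 (0.28 log units; that floor lies within the scatter), so a second carbon-only group joins cyclobutyl, though this floor also stays within the scatter. Compound 4 is reported only as a limit, > 1 h, and with compound 1 it sits at the top of the read-out: the limit of > 1 h in this assay, at which 2 of the 4 values shown sit. The step from compound 1 to compound 4 cannot be read.

As far as these compounds go, the true half-lives of compound 1 and compound 4 remain open. Also open, from the compounds shown here alone, is how a primary amine or a carboxylic acid on this sulfonyl sulfur would behave.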